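The compounds below may be only part of what the source reports. "The series", "measured", "known", "first", "only" and "open" are said of these compounds alone.

Compound 1, `CCOC(=O)[C@@H](N)CCC(=O)NCCSC(=O)C(C)(C)C`, in an ADME assay on liver for metabolic stability, with liver carboxylesterase 1 (Homo sapiens) as the target (on this read-out lower numbers stand for a shorter-lived compound and higher numbers for a longer-lived compound), compound 1 gives 0.167 h. Compound 2, `CCCCOC(=O)[C@@H](N)CCC(=O)NCCSC(=O)C(C)(C)C`, in this assay compound 2 gives 0.167 h.

Compound 1 stands level with compound 2 on the numbers shown: the step of no change at the digits printed from compound 1 to compound 2 (within the scatter) is within the scatter, and the change there is ethyl in place of hydrogen on a saturated chain carbon, two bonds along the chain from an oxygen next to a carbonyl group. Compound 3, `CCOC(=O)[C@@H](N)CCC(=O)NCCSC(C)=O`, differs from compound 1 by methyl in place of tert-butyl on a carbonyl carbon. Among the measured compounds shown here, no measured step touches the carbonyl carbon whose other neighbour is sulfur; the one step on record sits at the ester end and was flat. There is therefore no basis from the measured compounds for expecting a change beyond the scatter, and the step of a 1.1-fold lower number from compound 1 to compound 3 (0.05 log units; within the scatter) is expected to be small. Compound 3 is estimated to give 0.15 h in this assay, with a range from 0.07 h to 0.33 h.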

Compound 3, half-life in the liver carboxylesterase 1 assay: 0.167 h
The estimate for compound 3 lay 1.1-fold (0.05 log units) below the measured number, and the stated range covers the measured number.
By their numbers in the liver carboxylesterase 1 assay, from the lowest: compounds 1, 2 and 3 (each within the scatter of the next).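

In the liver carboxylesterase 1 assay, methyl in place of tert-butyl on a carbonyl carbon whose other neighbour is sulfur gives no change at the digits printed from compound 1 to compound 3 (within the scatter). This position therefore joins the ester end, where the earlier step was also flat. In a physicochemical assay for lipophilicity, measured as octanol-water partition, at pH 2 (a lower number here means a more polar compound, a higher number a more lipophilic compound), the same change does separate the two compounds, with compound 3 the more polar at a matching half-life: the measured partition coefficient of compound 1, 1.22, and of compound 3, 0.11, a number 1.11 log units lower (beyond the scatter) In the physicochemical assay compound 1 gives 1.22 and compound 3 gives 0.11.

The compounds shown leave open whether a phenyl ring or an amine on this carbonyl carbon would move the half-life beyond the scatter. They also leave open what a carboxylic acid in place of the ethyl ester would do to the half-life.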